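The source may hold more compounds than are shown below. What is called first, only, known or untested is meant among the compounds shown, and "the series" means these compounds.

Compound 1 `Clc1ccccc1/C=C/c1nnc(-c2ccc3c(c2)OCCO3)o1`: 7710 nM
Compound 2 `COc1ccc(/C=C/c2nnc(-c3ccc4c(c3)OCCO4)o2)cc1`: > 50000 nM (a limit)

In a functional assay on HUVEC cells (Homo sapiens) for antiproliferative activity, read by MTT assay, with a stated time of 48 h (on this read-out lower numbers stand for stronger inhibition and higher numbers for weaker inhibition), compound 2 gives > 50000 nM, which is a limit of the assay and not a number. Compound 3 `Fc1cccc(/C=C/c2nnc(-c3ccc4c(c3)OCCO4)o2)c1` has 3-fluorophenyl in place of 4-methoxyphenyl on a double-bonded chain carbon bound to a double-bonded chain carbon. Among the compounds with values here, one measured step bears on this change: an at least 6.4-fold higher number from compound 1 to compound 2 (0.81 log units; beyond the scatter). Compound 1, which also lacks 4-methoxyphenyl, gives 7710 nM, so a move toward stronger inhibition of similar size is expected. The expected change is an at least 3.3-fold lower number from compound 2 to compound 3 (0.52 log units; beyond the scatter). For compound 3 the estimated value is 15000 nM, with an expected range of 4000 nM to 50000 nM.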

Compound 3, half-maximal inhibitory concentration: 3530 nM
Compound 3: the middle estimate sits 4.2-fold (0.63 log units) above what was measured; measured number outside the range, below it.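

In this assay, 3-fluorophenyl in place of 4-methoxyphenyl gives an at least 14-fold lower number from compound 2 to compound 3 (1.15 log units; beyond the scatter), so the group at this place can shift the activity strongly. Swapping one halogen-bearing ring for another also matters, since 3-fluorophenyl in place of 2-chlorophenyl gives a 2.2-fold lower number from compound 1 to compound 3 (0.34 log units; beyond the scatter). The value of compound 2 is a limit and not a number, so the first step has no upper end: the limit of > 50000 nM in this assay, at which 1 of the 3 values shown sits.

Fluorine for chlorine and the change of ring position occur together in the second step, so the compounds shown cannot separate them. A 3-chlorophenyl group at this place would bear on that question.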